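Swapping the aryl group on the triazole nitrogen

The compounds below may be only part of what the source reports. "The series", "measured", "known", "first", "only" and "open" are said of these compounds alone.

Compound 1 `O=c1[nH]cc(S(=O)(=O)Nc2ccccc2-c2cn(-c3ccc(Cl)cc3)nn2)c(=O)[nH]1`: 1180 nM
Compound 2 `Cc1ccccc1-n1cc(-c2cccc(NS(=O)(=O)c3c[nH]c(=O)[nH]c3=O)c2)nn1`: 5470 nM
Compound 3 `O=c1[nH]cc(S(=O)(=O)Nc2cccc(-c3cn(-c4cccc(F)c4)nn3)c2)c(=O)[nH]1`: 7200 nM

Of the compounds shown here, three sharing one core have been measured in a functional assay on A549 cells (Homo sapiens) for antiproliferative activity, read by MTT assay, with a stated time of 24 h; a higher number here means a weaker inhibitor, a lower number a stronger inhibitor. Compound 3 gives the highest number of the three; the nearest is compound 2, which sits within the scatter of compound 3, while compound 1 sits well below it.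

Compound 4 `O=c1[nH]cc(S(=O)(=O)Nc2cccc(-c3cn(-c4ccc(Cl)cc4)nn3)c2)c(=O)[nH]1` is a new member of this series. Its change from compound 3 is 4-chlorophenyl in place of 3-fluorophenyl on an aromatic nitrogen. Going by the values given here, one measured step bears on this kind of exchange: a 1.3-fold higher number from compound 2 to compound 3 (0.12 log units; within the scatter), a change of the aryl group on the same nitrogen that stayed within the scatter. Compound 1 also carries a 4-chlorophenyl but differs from compound 4 elsewhere as well, so its value only shows that such a group can sit on a far stronger inhibitor.

On this basis compound 4 is expected to change little, a 1.3-fold lower number from compound 3 to compound 4 (0.12 log units; within the scatter), with the estimate for compound 4 being 5500 nM within a range from 2000 nM to 12000 nM.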

Compound 4, half-maximal inhibitory concentration: 1730 nM
Beside the measured number, compound 4's estimate is 3.2-fold (0.50 log units) above it; measured number outside the range, below it.
By their numbers in this assay, from the lowest: compounds 1 and 4 (each within the scatter of the next); then compounds 2 and 3 (each within the scatter of the next).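

This nitrogen is not as indifferent to its aryl group as the earlier step suggested: in this assay, 4-chlorophenyl in place of 3-fluorophenyl gives a 4.2-fold lower number from compound 3 to compound 4 (0.62 log units; beyond the scatter). The same group in place of 2-methylphenyl gives a 3.2-fold lower number from compound 2 to compound 4 (0.50 log units; beyond the scatter), so among compounds 2, 3 and 4 the 4-chlorophenyl stands apart from the other two aryl groups, which stay within the scatter of each other. Nothing measured here explains why this exchange shifts the number.

The compounds shown leave open whether the chlorine itself or its place on the ring matters, a question that a 4-fluorophenyl or a 3-chlorophenyl on the same nitrogen would address. They also leave open how far the trend extends, for example to a 4-bromophenyl or a 4-methoxyphenyl.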